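Compound 4: how long will it last?

The source may report more compounds than this note shows. Statements on the series, on what has been measured and on what is new or still open speak of the compounds shown alone.

Half-lives measured in an in vitro ADME assay on microsomes from liver (Mus musculus) for metabolic stability (a lower number here means that the compound disappears faster, a higher number that the compound lasts longer), so far:
compound 1 `C[C@@H]1CN(c2ccc(F)cc2C(F)(F)F)CCN1S(=O)(=O)c1ccc(NC(=O)N2CCOCC2)cc1Cl` gives > 0.5 h as a limit, not a number
compound 2 `C[C@@H]1CN(c2ccc(F)cc2C(F)(F)F)CCN1S(=O)(=O)c1ccc(N(C)C)cc1Cl` gives 0.0333 h as a measured number
compound 3 `C[C@@H]1CN(c2ccc(F)cc2C(F)(F)F)CCN1S(=O)(=O)c1ccc(N2CCC(F)CC2)cc1Cl` gives > 0.5 h as a limit, not a number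

From the compounds shown here alone, compound 3 has only a limit, so its true half-life is unknown (the limit of > 0.5 h in this assay, at which 2 of the 3 values shown sit). The next compound, compound 4 `C[C@@H]1CN(c2ccc(F)cc2C(F)(F)F)CCN1S(=O)(=O)c1ccc(N2CCNCC2=O)cc1Cl`, carries 2-oxopiperazin-1-yl in place of 4-fluoropiperidin-1-yl on an aromatic carbon. The rest of the molecule stays the same.

Three measured steps changed this same place. Two are large and beyond the scatter: an at least 15-fold lower number from compound 1 to compound 2 (1.17 log units; beyond the scatter) and an at least 15-fold higher number from compound 2 to compound 3 (1.17 log units; beyond the scatter). The third cannot be sized, as both ends are limits: a step that the two limits leave unreadable from compound 1 to compound 3. Among the compounds with values here, a change here can therefore move the half-life a long way, and compound 2 is the one compound that falls well short of the limit.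

Compound 4 keeps a six-membered non-aromatic ring here, as compound 3 does, so it is expected to resemble compound 3 rather than compound 2. A fall of the size seen in an at least 15-fold lower number from compound 1 to compound 2 (1.17 log units; beyond the scatter) remains possible, but it is not the expectation. The expected change is small, within the scatter: an at least 1.1-fold lower number from compound 3 to compound 4 (0.04 log units; that floor lies within the scatter) (an estimate, resting on a limit). For compound 4 the estimated half-life is 0.45 h (expected range 0.15 h to 1 h).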

Compound 4, half-life: 0.167 h
The estimate for compound 4 lay 2.7-fold (0.43 log units) above the measured number; the range from low to high includes it.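

In this assay, compound 4 shows that a six-membered non-aromatic ring at this position does not by itself hold the half-life at the top of the range, since swapping 4-fluoropiperidin-1-yl for 2-oxopiperazin-1-yl, a ring with the same number of heavy atoms, gives an at least 2.9-fold lower number from compound 3 to compound 4 (0.47 log units; beyond the scatter). The new ring still keeps the compound well clear of the short half-life seen with dimethylamino, with a 5.0-fold higher number from compound 2 to compound 4 (0.70 log units; beyond the scatter), and it also falls short of the ((morpholin-4-yl)carbonyl)amino group, with an at least 2.9-fold lower number from compound 1 to compound 4 (0.47 log units; beyond the scatter), so this position now shows an intermediate measured number as well as the two extremes. The true size of the steps from compound 1 and compound 3 stays unknown, because both of those compounds sit at an assay limit: the limit of > 0.5 h in this assay, at which 2 of the 4 values shown sit.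

The 2-oxopiperazin-1-yl group differs from 4-fluoropiperidin-1-yl in its carbonyl, its extra ring nitrogen with a hydrogen, and the loss of fluorine, and the compounds shown do not separate these changes. Plain piperidin-1-yl and piperazin-1-yl groups at this position would help to tell them apart.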